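Swapping the Pentyl Chain for a Thiourea Arm

A few compounds are considered here, and "the series" means these few. Any claim that something is new, unique, unknown or untested is made for them only; others in the source may bear on it.

Measured so far in an assay on VSM-A10 cells for antagonist activity at Endothelin-1 receptor (Rattus norvegicus); on this read-out lower numbers stand for stronger inhibition and higher numbers for weaker inhibition:
compound 1 `Cc1noc(NS(=O)(=O)c2cccc([N+](=O)[O-])c2)c1C` gives 7800 nM
compound 2 `Cc1noc(NS(=O)(=O)c2cccc3c(NCCCCCc4ccccc4)cccc23)c1C` gives 3050 nM

Compound 2 stands at the lower of the two numbers, and its gap to compound 1 lies beyond the scatter. Compound 3 `Cc1noc(NS(=O)(=O)c2cccc3c(N/C(S)=N/c4ccccc4)cccc23)c1C` is not yet measured. It differs from compound 2 by a group of 9 heavy atoms (7 carbon, 1 nitrogen, 1 sulfur; one six-membered aromatic ring of carbon only) in place of a group of 11 heavy atoms (11 carbon; one six-membered aromatic ring of carbon only), on a nitrogen on an aromatic ring. Going by the values given here, no measured pair shows this kind of change, so no direction is established. In this assay a step from compound 2 of modest size, in either direction, is expected, likely within the scatter. For compound 3 the expected value is 4000 nM, with a range from 1000 nM to 15000 nM, corresponding to an estimated step of a 1.3-fold higher number from compound 2 to compound 3 (0.12 log units; within the scatter).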

Compound 3, half-maximal inhibitory concentration: 150 nM
The estimate for compound 3 lay 27-fold (1.43 log units) above the measured number, outside the stated range (below it).
By their numbers in this assay, from the lowest: compound 3; then compound 2; then compound 1.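

Going by these compounds alone, at the nitrogen on the aromatic ring, the choice of group has far more effect than the earlier compounds could show: in this assay, replacing 5-phenylpentyl with the thiourea arm gives a 20-fold lower number from compound 2 to compound 3 (1.31 log units; beyond the scatter) and this step is large. Both groups carry a six-membered aromatic ring of carbon only, so what differs is how that ring is linked to the nitrogen. Nothing available explains why the number fell.

A urea, with oxygen in place of sulfur, would show whether the sulfur matters. A thiourea with a methyl group in place of the phenyl ring would show whether that ring is needed.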